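A few compounds are considered here, and "the series" means these few. Any claim that something is new, unique, unknown or untested is made for them only; others in the source may bear on it.

Compound 1 `CCCC#Cc1cc([C@@H]2O[C@H](CO)[C@@H](O)[C@H]2O)n2ncnc(N)c12` is the starting point. Going by the values given here, in a functional assay on LN-229 cells (Homo sapiens) for antiproliferative activity, with a stated time of 72 h (a lower number here means a stronger inhibitor, a higher number a weaker inhibitor), compound 1 gives 40 nM, the lowest of the three numbers measured so far. Compound 2 `CCCCC#Cc1cc([C@@H]2O[C@H](CO)[C@@H](O)[C@H]2O)n2ncnc(N)c12` gives 1000 nM in this assay, and compound 3 `Nc1ncnn2c([C@@H]3O[C@H](CO)[C@@H](O)[C@H]3O)cc(-c3ccc(Cl)cc3)c12` gives 32600 nM. The step of a 25-fold higher number from compound 1 to compound 2 (1.40 log units; beyond the scatter) shows that even a small change to the chain weakens inhibition markedly, while an 820-fold higher number from compound 1 to compound 3 (2.91 log units; beyond the scatter) and a 33-fold higher number from compound 2 to compound 3 (1.51 log units; beyond the scatter) show that exchanging the chain for an aromatic ring weakens it far more.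

Compound 4 `Nc1ncnn2c([C@@H]3O[C@H](CO)[C@@H](O)[C@H]3O)cc(-c3ccccc3Cl)c12` is not yet measured. Its change from compound 1 is 2-chlorophenyl in place of pent-1-yn-1-yl on an aromatic carbon. Among the compounds with values here, the closest precedent is the step to compound 3, where a 4-chlorophenyl group took the place of the same chain and the number rose by an 820-fold higher number from compound 1 to compound 3 (2.91 log units; beyond the scatter). Within the data shown here, compound 4 carries its chlorine on the ring in a different position, and no measured pair shows what that shift alone does, so the expectation rests on the ring-for-chain exchange. A large rise in the number is therefore expected for compound 4, in the direction of weaker inhibition, on the order of a 500-fold higher number from compound 1 to compound 4 (2.70 log units; beyond the scatter). Compound 4 is estimated at 20000 nM in this assay, with a range from 4000 nM to 80000 nM.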

Compound 4, half-maximal inhibitory concentration: > 100000 nM
Compound 4: a limit, no number; the forecaster's own chance of this, stated with the estimate: 10%; middle value at least 5.0-fold (0.69 log units) from the limit.
By their numbers in this assay, from the lowest: compound 1; then compound 2; then compound 3. At a limit, above all of these: compound 4.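

Compound 4 gives no number in this assay, only a limit: the limit of > 100000 nM in this assay, at which 1 of the 4 values shown sits. What is new is that the position of the chlorine on the ring matters at this aromatic carbon, as moving from 4-chlorophenyl to 2-chlorophenyl gives an at least 3.0-fold higher number from compound 3 to compound 4 (0.48 log units; beyond the scatter), so these two groups are not interchangeable here. Against the alkyne chains the exchange costs even more, with an at least 2500-fold higher number from compound 1 to compound 4 (3.39 log units; beyond the scatter) and an at least 100-fold higher number from compound 2 to compound 4 (2.00 log units; beyond the scatter), and each of these three steps gives only a minimum size.

The compounds shown leave open whether any aromatic ring can approach the alkyne chains at this carbon, since an unsubstituted phenyl or a 3-chlorophenyl group would show whether the chlorine or the ring itself accounts for most of the loss. They also leave open how a shorter chain such as but-1-yn-1-yl, or a chain ending in a hydroxyl group or an amine, would compare with the pent-1-yn-1-yl group of compound 1, which gives 40 nM.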